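The source may hold more compounds than are shown below. What is called first, only, known or untested is meant among the compounds shown, and "the series" means these compounds.

Compound 1 `CCCCCCCCCCc1ccc(-c2noc(CCCN)n2)cc1` gives 67% in an assay on HeLa cells for inhibition of sphingosine-1-phosphate transporter SPNS2 (Mus musculus), read by LC-MS, tested at 2 uM; a lower number here means less inhibition, a higher number more inhibition at the concentration tested (going by the name of the read-out).
Compound 2 `CCCCCCCCCCc1ccc(-c2noc([C@@H]3CCCN3)n2)cc1` gives 21% in this assay.
Compound 3 `CCCCCCCCCCc1ccc(-c2noc([C@@H](N)CCCN)n2)cc1` gives 40% in this assay.

Among these three numbers compound 3 stands second highest. Its nearest neighbour is compound 2, reached by the step of a number 19 percentage points higher from compound 2 to compound 3 (beyond the scatter); the furthest is compound 1, since a number 27 percentage points lower from compound 1 to compound 3 (beyond the scatter). Both of these gaps lie beyond the scatter, so the order among the three holds.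

The next compound, compound 4 `CCCCCCCCCCc1ccc(-c2noc(CC(O)CN3CCCC3)n2)cc1`, has not yet been measured in this assay. It is built from compound 3 by one change: 2-hydroxy-3-(pyrrolidin-1-yl)propyl in place of 1,4-diaminobutyl on an aromatic carbon. Among the compounds with values here, no measured step covers exactly this exchange. Within the data shown here, the steps that bear on it are those at the same place: a number 46 percentage points lower from compound 1 to compound 2 (beyond the scatter), a large drop, and a number 19 percentage points higher from compound 2 to compound 3 (beyond the scatter), a modest rise. Together they show that the number in this assay swings widely with the group at this position, and that the open-chain groups of compound 1 and compound 3 give higher numbers than the ring of compound 2. Compound 4 carries a ring again, though with a hydroxyl-bearing chain, so a downward step from compound 3 is expected, of uncertain size. The estimate for compound 4 is 32%, with a range from 8% to 58%, meaning a number 8 percentage points lower from compound 3 to compound 4 (within the scatter).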

Compound 4, a percentage reported as inhibition, at one concentration (the size of the read-out at that concentration, not a potency): 21%
Compound 4: middle estimate off by 11 percentage points, on the high side; the range from low to high includes it.
By their numbers in this assay, from the lowest: compounds 2 and 4 (each within the scatter of the next); then compound 3; then compound 1.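

Putting 2-hydroxy-3-(pyrrolidin-1-yl)propyl in place of 1,4-diaminobutyl gives a number 19 percentage points lower from compound 3 to compound 4 (beyond the scatter) in this assay, while the same group in place of pyrrolidin-2-yl gives no change at the digits printed from compound 2 to compound 4 (within the scatter), so at this position on the five-membered aromatic ring a larger, hydroxyl-bearing group with a ring stands level with the smaller ring group. Against the 3-aminopropyl group, the result is a number 46 percentage points lower from compound 1 to compound 4 (beyond the scatter), and across the four compounds the two groups with a pyrrolidine ring, in compound 2 and compound 4, give lower numbers than the two open-chain amines, in compound 1 and compound 3, with no compound here going against this. Nothing at hand says why these groups separate in this way.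

Going by these compounds, it remains open whether the low number of compound 4 goes with the hydroxyl or with the pyrrolidine ring, which a 3-(pyrrolidin-1-yl)propyl group or a 3-amino-2-hydroxypropyl group at the same position could separate. On these data alone, it is also open how a longer primary amine, such as 4-aminobutyl, would compare with the 3-aminopropyl group of compound 1.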